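A few compounds are considered here, and "the series" means these few. Any claim that something is new, unique, unknown or untested is made for them only; others in the source may bear on it.

Measured so far:
compound 1 `Cc1cc(C(N)=O)nn1Cc1cc(Cl)ccc1OCc1ccccc1` — 126 nM
compound 2 `Cc1cc(C(=O)Nc2ccccc2)nn1Cc1cc(Cl)ccc1OCc1ccccc1` — 39.8 nM

In an assay on CHO-K1 cells for displacement of a labelled ligand from prostaglandin E2 receptor EP1 subtype (Homo sapiens) (on this read-out lower numbers stand for stronger inhibition and higher numbers for weaker inhibition), compound 1 gives 126 nM, the highest of the two numbers; its nearest neighbour is compound 2, which in this assay gives 39.8 nM. Going by the values given here, the one step measured between these two is a 3.2-fold lower number from compound 1 to compound 2 (0.50 log units; beyond the scatter), so adding a phenyl onto the amide-type nitrogen of compound 1 helped modestly.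

Compound 3 `Cc1cc(NC(=O)c2c(F)cccc2F)nn1Cc1cc(Cl)ccc1OCc1ccccc1` has not yet been measured in this assay. It differs from compound 1 in one place: ((2,6-difluorophenyl)carbonyl)amino in place of carbamoyl on an aromatic carbon. This change resembles the step to compound 2 in that a six-membered aromatic ring of carbon only is brought into the group on that aromatic carbon, here carrying two fluorine; it differs in that the carbamoyl itself leaves, whereas in compound 2 it stays. Because a 3.2-fold lower number from compound 1 to compound 2 (0.50 log units; beyond the scatter) was a modest gain beyond the scatter, a gain of similar size is expected for compound 3, with wider uncertainty since the change is of a different kind. Compound 3 is therefore estimated at 50 nM (range 15 nM to 200 nM), which would mean a step of a 2.5-fold lower number from compound 1 to compound 3 (0.40 log units; beyond the scatter).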

Compound 3, half-maximal inhibitory concentration: 12.6 nM
The estimate for compound 3 lay 4.0-fold (0.60 log units) above the measured number; the measured number lies below the stated range.
By their numbers in this assay, from the lowest: compound 3; then compound 2; then compound 1.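

In this assay the aromatic carbon next to the ring nitrogen accepts a much larger group, one joined through its nitrogen instead of through its carbonyl carbon, and the number still falls, with a 10-fold lower number from compound 1 to compound 3 (1.00 log units; beyond the scatter) as the step. Compound 3 also improves on the phenyl amide, with a 3.2-fold lower number from compound 2 to compound 3 (0.50 log units; beyond the scatter) as the step, so across these three compounds a carbonyl carbon attached directly to this ring is not needed for a low number, and a carbamoyl group is not needed either. Nothing measured here explains why this change lowers the number.

On these data alone, compound 3 differs from compound 2 in both the direction of the amide link and the two fluorine atoms, so the contribution of each stays unknown. The plain (phenylcarbonyl)amino group, without fluorine, would separate the two, while an acetylamino group or a carboxylic acid on the same aromatic carbon would show how much of the result depends on the aromatic ring and on the amide itself.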